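The source may hold more compounds than are shown below. What is called first, only, known or untested is meant among the compounds shown, and "the series" means these compounds.

Among the compounds with values here, in an ADME assay on Vero cells (Chlorocebus sabaeus) for cytotoxicity, read by CellTiter-Glo, with a stated time of 72 h (on this read-out higher numbers stand for lower toxicity in this test and lower numbers for higher toxicity in this test), compound 1 (`[O-][n+]1nc(NC2CCC2)[n+]([O-])c2ccccc21`) gives 8.9 ug/mL and stands second highest of the three numbers measured so far. Compound 2 (`[O-][n+]1nc(NC2CCC2)[n+]([O-])c2ccc(F)cc21`) gives 1.6 ug/mL and compound 3 (`Cc1cccc2c1[n+]([O-])c(NC1CCC1)n[n+]2[O-]`) gives 22 ug/mL in the same test. The measured steps are a 5.6-fold lower number from compound 1 to compound 2 (0.75 log units; beyond the scatter) for fluoro in place of hydrogen and a 2.5-fold higher number from compound 1 to compound 3 (0.39 log units; beyond the scatter) for methyl in place of hydrogen, both modest yet beyond the scatter. Compound 4 (`[O-][n+]1nc(N2CCCC2)[n+]([O-])c2ccccc21`) instead carries pyrrolidin-1-yl in place of cyclobutylamino on an aromatic carbon between two ring nitrogen atoms. Neither measured step touches this place, so they serve only as a gauge of size, and no change beyond the scatter is expected in this assay in either direction. The expected step is a 1.1-fold lower number from compound 1 to compound 4 (0.05 log units; within the scatter) and no more. For compound 4 the estimated value is 8 ug/mL with an expected range from 3 ug/mL to 22 ug/mL in this test.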

Compound 4, half-maximal cytotoxic concentration: 17 ug/mL
Compound 4: middle estimate off by 2.1-fold (0.33 log units), on the low side, and the stated range covers the measured number.
By their numbers in this assay, from the lowest: compound 2; then compounds 1, 4 and 3 (each within the scatter of the next, the first and the last beyond it).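

Within the data shown here, the first change at this place, on an aromatic carbon between two ring nitrogen atoms, gives a 1.9-fold higher number from compound 1 to compound 4 (0.28 log units; within the scatter) in this assay. Cyclobutylamino has 1 hydrogen-bond donor and pyrrolidin-1-yl has 0 hydrogen-bond donors, yet this step stays within the scatter, unlike the fluoro and methyl steps on the aromatic ring. Nothing available explains this result.

From the compounds shown here alone, whether an open-chain group such as diethylamino, or a morpholine ring, would behave the same way here remains open. So does whether the fluoro and methyl steps would carry over to the pyrrolidin-1-yl series.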